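Three limit values and a piperidine analogue to follow

The source may hold more compounds than are shown below. What is called first, only, known or untested is meant among the compounds shown, and "the series" means these compounds.

compound 1 `CC(C)N(C(=O)CCNC(=O)c1ccc(S(C)(=O)=O)c([N+](=O)[O-])c1)C(C)C`: in an assay on isolated protein for inhibition of vitamin D3 receptor (Homo sapiens), read by fluorescence polarization (a higher number here means a weaker inhibitor, a lower number a stronger inhibitor), compound 1 gives > 60000 nM
compound 2 `CN(CC(=O)N(Cc1ccccc1)Cc1ccccc1)C(=O)c1ccc(S(C)(=O)=O)c([N+](=O)[O-])c1`: compound 2 gives > 60000 nM
compound 3 `CS(=O)(=O)c1ccc(C(=O)NCC(=O)N2CCN(c3ccccc3F)CC2)cc1[N+](=O)[O-]`: compound 3 gives > 60000 nM

Each of the three values is a limit of this assay, not a number. Compound 1 stands at the limit of > 60000 nM in this assay, at which 3 of the 3 values shown sit. For the measured compounds named here, compound 2 and compound 3 sit at the same limit, so no order among the three can be read and no measured step exists in this set. Where compound 1 stands is therefore known only as a limit, with no number attached.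

Compound 4 `CS(=O)(=O)c1ccc(C(=O)NCCC(=O)N2CCCCC2)cc1[N+](=O)[O-]` is the next compound to be measured. Relative to compound 1 it carries piperidin-1-yl in place of diisopropylamino on a carbonyl carbon. The rest of compound 1 is unchanged. Going by the values given here, nothing among the measured values shows that the amine part of that amide moves potency in either direction, since every value so far is a limit. The step expected is a number no higher from compound 1 to compound 4 (the limit leaves the size open), none beyond the scatter. Compound 4 is expected to return a limit again, estimated at 60000 nM with a range from 30000 nM to 200000 nM. Should a number appear instead, it would be the first in the set and would stand on its own.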

Compound 4, half-maximal inhibitory concentration: > 60000 nM
Compound 4: no number, only a limit; the forecaster's own chance of this, stated with the estimate: 85%; the middle value sits exactly at the limit.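

In this assay compound 4 gives > 60000 nM, a limit and not a number. Compound 1 also stands only at a limit, so no step can be read between compound 1 and compound 4. The compounds shown leave open whether any change to the amine part of the amide moves potency in this assay.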